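This account rests on a few compounds, and the source may have more. Where it says the series, first, only, none or still open, it means among the compounds named here.

Measured so far in a functional assay for inhibition, with Homo sapiens as the target; a higher number here means a weaker inhibitor, a lower number a stronger inhibitor:
compound 1 `C=CCn1ncc2c(C)nc(CCC)n2c1=O` — compound 1 gives 40000 nM;
compound 2 `CCOC(=O)Cn1ncc2c(C)ncn2c1=O` — compound 2 gives > 48000 nM.

Compound 2 stands at the limit: this value is not a number but a limit of the assay, (the limit of > 48000 nM in this assay, at which 1 of the 2 values shown sits). Compound 1, by contrast, gives a number, though a high one.

The step to compound 3 `C=CCn1ncc2c(C)ncn2c1=O` is vinyl in place of ethoxycarbonyl on a saturated chain carbon bound to an aromatic nitrogen. Among the measured compounds shown here, no measured pair shows this change alone, and compound 1 and compound 2 differ in more than one place, so they cannot be read as this step.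

Compound 3 carries the same vinyl-bearing chain as compound 1, for which 40000 nM was found, so weak inhibition of a similar order is expected. The step from compound 2 to compound 3 is expected to be a step that the limit leaves unreadable from compound 2 to compound 3, a change not clearly beyond the scatter. For compound 3 the estimate is 60000 nM, ranging from 20000 nM to 200000 nM.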

Compound 3, half-maximal inhibitory concentration: > 48000 nM
Compound 3 gave a limit, no number (the forecaster's own chance of this, stated with the estimate: 55%); the middle value is on the limit's open side.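

Among the compounds shown here, replacing propyl with hydrogen on an aromatic carbon is the first single change that can be read in this assay, and it gives an at least 1.2-fold higher number from compound 1 to compound 3 (0.07 log units; that floor lies within the scatter). This reading does not establish that the propyl group matters, since the true size of the step could be larger but is hidden by the limit. The change of ethoxycarbonyl to vinyl on a saturated chain carbon bound to an aromatic nitrogen, now isolated for the first time, cannot be read, since compound 2 and compound 3 both stand at the same limit: the limit of > 48000 nM in this assay, at which 2 of the 3 values shown sit.

Open, as far as these compounds go, is whether a longer chain such as butyl or a phenyl group on that aromatic carbon would give a lower number than compound 1. Also open, from the compounds shown here alone, is whether an amine or a carboxylic acid on the saturated chain carbon would bring compound 3 into the measurable range.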